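A few compounds are considered here, and "the series" means these few. Any claim that something is new, unique, unknown or untested is made for them only; others in the source may bear on it.

Within the data shown here, in a functional assay on Raji cells (Homo sapiens) for antiproliferative activity, read by MTT assay, with a stated time of 6 days (a higher number here means a weaker inhibitor, a lower number a stronger inhibitor), three esters built on one shared core have numbers so far. Compound 1 `O=C1C=C[C@@H](OCc2ccccc2)[C@@H]([C@@H](COC(=O)/C=C/c2ccccc2)OCc2ccccc2)O1` gives 1330 nM, compound 2 `O=C1C=C[C@@H](OCc2ccccc2)[C@@H]([C@@H](COC(=O)/C=C/c2ccc(F)cc2)OCc2ccccc2)O1` gives 2470 nM, and compound 3 `O=C1C=C[C@@H](OCc2ccccc2)[C@@H]([C@@H](COC(=O)/C=C/c2ccc([N+](=O)[O-])cc2)OCc2ccccc2)O1` gives 140 nM. The place of compound 2 is at the weak end of this small set: a 1.9-fold higher number from compound 1 to compound 2 (0.27 log units; within the scatter), and an 18-fold lower number from compound 2 to compound 3 (1.25 log units; beyond the scatter).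

Compound 4 `O=C1C=C[C@@H](OCc2ccccc2)[C@@H]([C@@H](CO)OCc2ccccc2)O1` takes away the whole ester side group: hydrogen in place of (2-(4-fluorophenyl)ethenyl)carbonyl on an oxygen on a saturated carbon. In words, hydrogen comes in place of (2-(4-fluorophenyl)ethenyl)carbonyl on an oxygen on a saturated carbon.

The measured steps only swap a group on the aromatic ring, and the nitro swap a 9.5-fold lower number from compound 1 to compound 3 (0.98 log units; beyond the scatter) shows that this part of the molecule can matter in this assay. Among the measured compounds shown here, no measured compound lacks the side group, however, so these steps give neither a size nor a direction for its removal. The best expectation is therefore no step beyond the scatter, with wide uncertainty on both sides.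

Compound 4 is estimated at 2500 nM, with an expected range of 500 nM to 12000 nM. This estimate means an expected 1.0-fold higher number from compound 2 to compound 4 (0.01 log units; within the scatter).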

Compound 4, half-maximal inhibitory concentration: 10 nM
The estimate for compound 4 lay 250-fold (2.40 log units) above the measured number; the measured number lies below the stated range.
By their numbers in this assay, from the lowest: compound 4; then compound 3; then compounds 1 and 2 (each within the scatter of the next).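

Until now, only changes on the aromatic ring of the ester side group had been seen to move the number in this assay. Replacing the whole side group with hydrogen, which leaves a hydroxy on the saturated chain carbon, gives a 250-fold lower number from compound 2 to compound 4 (2.39 log units; beyond the scatter), and removing the unsubstituted (2-phenylethenyl)carbonyl group gives a 130-fold lower number from compound 1 to compound 4 (2.12 log units; beyond the scatter), so in these two pairs the ester side group is not needed for activity and its presence goes with a much weaker result. Nothing measured here bears on why the number falls so far.

On these data alone, it remains open whether the free hydroxy itself matters or only the loss of the large ester, which a methyl ether or an amine at this place could help to separate. A small acetyl ester could likewise show how much of the side group can return before the number rises.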